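The source may hold more compounds than are shown below. What is called first, only, known or untested is meant among the compounds shown, and "the series" means these compounds.

Among the compounds with values here, in a functional assay on Daoy cells (Homo sapiens) for antiproliferative activity, read by trypan blue exclusion and crystal violet staining, with a stated time of 72 h (a higher number here means a weaker inhibitor, a lower number a stronger inhibitor), compound 1 (`O=C(NCc1ccc2cccnc2c1O)C1CCCCC1`) gives 720 nM as the only number available in this small set. Compound 2 (`CCCCC(=O)NCc1ccc2cccnc2c1O`) offers no comparison: for compound 2 the entry reads "nd" (no result reported) with no result reported. Compound 3 (`O=C(NC(c1ccc(Cl)cc1Cl)c1ccc2cccnc2c1O)C1CCCCC1`) keeps the core of compound 1 and differs in one place: a 2,4-dichlorophenyl enters in place of hydrogen on the saturated chain carbon bound to an amide-type nitrogen and an aromatic carbon (2,4-dichlorophenyl in place of hydrogen on a saturated chain carbon bound to an amide-type nitrogen and an aromatic carbon). Within the data shown here, no measured step shows what such an addition does, so in this assay only a modest gain in potency is expected, close to the scatter, and a loss cannot be excluded. The expected size is that of the estimated step (a 1.6-fold lower number from compound 1 to compound 3 (0.20 log units; within the scatter)). For compound 3 the estimated value is 450 nM with an expected range from 120 nM to 1800 nM in this measurement.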

Compound 3, half-maximal inhibitory concentration: 240 nM
Beside the measured number, compound 3's estimate is 1.9-fold (0.27 log units) above it; the measured number falls inside the stated range.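

In this assay, within the data shown here, the first measured change at this position gives a 3.0-fold lower number from compound 1 to compound 3 (0.48 log units; beyond the scatter) with 2,4-dichlorophenyl in place of hydrogen on the saturated chain carbon bound to an amide-type nitrogen and an aromatic carbon. Until now this carbon had been seen carrying only hydrogen, and the result shows that it can take this large aromatic substituent with a gain in potency rather than a loss. Nothing available explains the gain.

Only one substituent is shown at this carbon, so it remains open whether the gain comes from the aromatic ring or from its two chlorines, a question that plain phenyl could help settle. Also open, going by these compounds, is whether a smaller group such as methyl, or an amine, would be tolerated at this carbon.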